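Chloro to Bromo on the Phenol Ring of Compound 1

The source may hold more compounds than are shown below. What is called first, only, known or untested is meant among the compounds shown, and "the series" means these compounds.

Compound 1: `CN(C)C(=O)N(Cc1ccco1)Cc1cc(Cl)ccc1O` — 28600 nM
Compound 2: `CCOC(=O)N1CCC(N(Cc2cc(Cl)ccc2O)C(=O)N(C)C)CC1` — 38400 nM
Compound 3: `CN(C)C(=O)N(Cc1ccc(O)cc1)Cc1ccco1` — 18600 nM

Of the compounds shown here, three have been measured in a functional assay on K562 cells (Homo sapiens) for antiproliferative activity, read by MTT assay, with a stated time of 48 h; on this read-out higher numbers stand for weaker inhibition and lower numbers for stronger inhibition. Among them, compound 1 gives the second highest of the three numbers. Its nearest neighbour is compound 2, whose number lies within the scatter of that of compound 1, and the furthest is compound 3, whose number also lies within the scatter. On these numbers, then, the three compounds cannot be told apart.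

The unmeasured compound 4 has the structure `CN(C)C(=O)N(Cc1ccco1)Cc1cc(Br)ccc1O` and differs from compound 1 in one place: bromo in place of chloro on an aromatic carbon. Within the data shown here, no step between measured compounds follows this change, so there is nothing measured to set its size. Among the measured compounds shown here, a halogen-for-halogen swap of this kind generally moves the number little, and the values of compound 1, compound 2 and compound 3 show that the series so far sits in a narrow band. The step from compound 1 to compound 4 is therefore expected to be small, in no settled direction, and not beyond the scatter: a 1.1-fold lower number from compound 1 to compound 4 (0.06 log units; within the scatter).

In this assay, compound 4 is estimated to give 25000 nM, within a range from 10000 nM to 60000 nM.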

Compound 4, half-maximal inhibitory concentration: 40500 nM
For compound 4 the middle estimate is 1.6-fold (0.21 log units) below the measured one; measured number inside the range.
By their numbers in this assay, from the lowest: compounds 3, 1, 2 and 4 (each within the scatter of the next, the first and the last beyond it).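

Within this assay the exchange of chloro for bromo, on the aromatic carbon para to a hydroxy group and meta to a large group, gives the first step that can be read at this position, a 1.4-fold higher number from compound 1 to compound 4 (0.15 log units; within the scatter), and this step lies within the scatter. On the core of compound 1, then, this one halogen swap leaves the antiproliferative read-out indistinguishable from that of the chloro compound, with no hydrogen-bond donor, hydrogen-bond acceptor or net charge entering or leaving. No available evidence bears on this result.

The compounds shown leave open whether another group at this position, such as fluoro, methoxy, an amine or a carboxylic acid, would move the number beyond the scatter. They also leave open whether bromo in place of chloro would give a step of similar size on the core of compound 2, where the furan-free piperidine carbamate side of the molecule differs from that of compound 1.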